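Taking Away a Trifluoromethyl Group: What to Expect

The compounds below may be only part of what the source reports. "The series", "measured", "known", "first", "only" and "open" are said of these compounds alone.

Three compounds built on one shared core have been run in an ADME assay on microsomes from liver (Rattus norvegicus) for metabolic stability, read by LC-MS; a higher number here means faster removal of the compound, a lower number slower removal. Compound 1 `COc1cc(N2CCN(C(=O)Cn3ncc4ccccc43)CC2)ccc1-c1cnc(C)o1` gives 77 mL.min-1.g-1. For the measured compounds named here, compound 2 `COc1cc(N2CCN(C(=O)CN3CCc4ccccc43)CC2)ccc1-c1cnc(C)o1` gives 160 mL.min-1.g-1, and the only paired change among the measured compounds is a 2.1-fold higher number from compound 1 to compound 2 (0.32 log units; beyond the scatter). Compound 3 `COc1cc(N2CCN(C(=O)Cn3cnc4cc(C(F)(F)F)ccc43)CC2)ccc1-c1cnc(C)o1` gives 66 mL.min-1.g-1, a number that lies within the scatter of compound 1, while the value of compound 2 stands beyond the scatter above it.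

Compound 4 `COc1cc(N2CCN(C(=O)Cn3cnc4ccccc43)CC2)ccc1-c1cnc(C)o1` differs from compound 3 in a single place: hydrogen in place of trifluoromethyl on an aromatic carbon. Going by the values given here, no measured step removes a trifluoromethyl or alters a six-membered aromatic ring of carbon only; the one step in hand, a 2.1-fold higher number from compound 1 to compound 2 (0.32 log units; beyond the scatter), exchanges whole ring systems on the saturated chain carbon and so speaks to this change only loosely. With nothing pointing in either direction, the step from compound 3 to compound 4 is expected to stay within the scatter, and the expected step is a 1.1-fold higher number from compound 3 to compound 4 (0.06 log units; within the scatter). On that basis compound 4 is estimated to give 75 mL.min-1.g-1 in this assay, with a range from 38 mL.min-1.g-1 to 150 mL.min-1.g-1.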

Compound 4, intrinsic clearance in microsomes: 22 mL.min-1.g-1
The estimate for compound 4 lay 3.4-fold (0.53 log units) above the measured number; the whole stated range lies above it.
By their numbers in this assay, from the lowest: compound 4; then compounds 3 and 1 (each within the scatter of the next); then compound 2.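

In this assay, for the compounds shown here, this aromatic carbon proves sensitive to its substituent: hydrogen in place of trifluoromethyl gives a 3.0-fold lower number from compound 3 to compound 4 (0.48 log units; beyond the scatter) and so marks slower removal, something the earlier compounds could not show because none of them differed at this position. Compound 4 also sets 1H-benzimidazol-1-yl apart from the other two ring systems on the saturated chain carbon, since replacing 2,3-dihydro-1H-indol-1-yl gives a 7.3-fold lower number from compound 2 to compound 4 (0.86 log units; beyond the scatter) and replacing 1H-indazol-1-yl gives a 3.5-fold lower number from compound 1 to compound 4 (0.54 log units; beyond the scatter) in the same read-out. Nothing available explains why these changes lower the number.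

The compounds shown leave open what a chlorine atom, a nitrile or a methoxy group on this same aromatic carbon would do, so it remains unclear whether the number follows the size of the substituent or is specific to trifluoromethyl. They also leave open whether adding trifluoromethyl to the six-membered aromatic ring of carbon only in compound 1 would produce a similar step, or whether this effect belongs to the 1H-benzimidazol-1-yl series alone.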